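Swapping the alkyne substituent in a bicyclic nucleoside series

The compounds below may be only part of what the source reports. "The series", "measured", "known", "first", "only" and "open" are said of these compounds alone.

This account covers three compounds of a shared core that were examined for cytotoxicity, together with a fourth that remains to be tested. Compound 1 `CCCCCc1ccc(-c2oc3nc(=O)n([C@H]4C[C@H](OC(C)=O)[C@@H](COC(C)=O)O4)cc3c2C#Cc2ccc(C)cc2)cc1` carries a 4-methylphenyl group on the alkyne; for compound 1 the result in an ADME assay on HEL cells (Homo sapiens) for cytotoxicity, read by cell counting, with a stated time of 3 days (on this read-out lower numbers stand for higher toxicity in this test and higher numbers for lower toxicity in this test), is "not determined" (no result reported). Compound 3 `CC(=O)OC[C@H]1O[C@@H](n2cc3c(C#CCO)c(-c4ccc(C)cc4)oc3nc2=O)C[C@@H]1OC(C)=O` bears a shorter hydroxymethyl-terminated alkyne; in this assay compound 3 gives "not determined" (no result reported). Compound 2 `CCCCCc1ccc(C#Cc2c(-c3ccc(CCCCC)cc3)oc3nc(=O)n([C@H]4C[C@H](OC(C)=O)[C@@H](COC(C)=O)O4)cc23)cc1` is therefore the only one with a reported read-out. In this assay compound 2 gives > 100000 nM, which is a limit of the assay rather than a number, and it matches (the limit of > 100000 nM in this assay, at which 1 of the 3 values shown sits).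

The step to compound 4 `CCCCCc1ccc(-c2oc3nc(=O)n([C@H]4C[C@H](OC(C)=O)[C@@H](COC(C)=O)O4)cc3c2C#CCCO)cc1` changes the alkyne terminus: 2-hydroxyethyl in place of 4-pentylphenyl on a triple-bonded carbon. Among the measured compounds shown here, no measured step is available for comparison. Given that compound 2 sits at > 100000 nM, the expectation is that the change from compound 2 to compound 4 produces no shift beyond the scatter in this assay, estimated as a number no higher from compound 2 to compound 4 (the limit leaves the size open). Compound 4 is accordingly expected to give about 100000 nM, within a range from 30000 nM to 300000 nM.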

Compound 4, half-maximal cytotoxic concentration: 2660 nM
For compound 4 the middle estimate is 38-fold (1.58 log units) above the measured one; measured number outside the range, below it.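

In this assay, the exchange of 4-pentylphenyl for 2-hydroxyethyl on a triple-bonded carbon gives an at least 37-fold lower number from compound 2 to compound 4 (1.57 log units; beyond the scatter). Among the compounds shown here, this is the first comparison, and it shows that a change at this one place, with the rest of the molecule held the same, can move the read-out well beyond the scatter, towards higher toxicity in this test. The value for compound 2 is a limit, so the step sets only a minimum size: the limit of > 100000 nM in this assay, at which 1 of the 4 values shown sits.

This single step removes the aromatic ring and brings in the hydroxyl group together, so it cannot say which of the two matters. A plain pentyl chain at this place, or an amine in place of the hydroxyl group, would begin to separate them.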